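Methyl entering the five-membered ring of compound 3

The source may hold more compounds than are shown below. What is called first, only, known or untested is meant among the compounds shown, and "the series" means these compounds.

Among the compounds with values here, compound 3 `CC(C)c1cc(Cn2ccc3cc(OCC(=O)O)cc(Cl)c32)ccc1O` holds the lowest number of the three measured so far: in an assay on HeLa cells for displacement of a labelled ligand from thyroid hormone receptor beta (Homo sapiens) (on this read-out lower numbers stand for stronger inhibition and higher numbers for weaker inhibition), compound 3 gives 0.07 nM. Compound 2 `Cc1cc(OCC(=O)O)cc2ccn(Cc3ccc(O)c(C(C)C)c3)c12` gives 0.26 nM and compound 1 `CC(C)c1cc(Cn2ccc3cc(OCC(=O)O)ccc32)ccc1O` gives 1.04 nM in this assay, so the step from compound 1 to compound 3 a 15-fold lower number from compound 1 to compound 3 (1.17 log units; beyond the scatter) and the step from compound 2 to compound 3 a 3.7-fold lower number from compound 2 to compound 3 (0.57 log units; beyond the scatter) both lie beyond the scatter.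

Compound 4 `Cc1cc2cc(OCC(=O)O)cc(Cl)c2n1Cc1ccc(O)c(C(C)C)c1` differs from compound 3 by methyl in place of hydrogen on an aromatic carbon; the entering methyl sits on an aromatic carbon of a five-membered aromatic ring with one nitrogen, next to the ring nitrogen and next to the ring atom that bears a large group. Within the data shown here, no measured step touches that carbon. Among the measured compounds shown here, the only methyl step, from compound 1 to compound 2 a 4.0-fold lower number from compound 1 to compound 2 (0.60 log units; beyond the scatter), concerns a different aromatic carbon, and the chloro steps give no guidance on a methyl here. A step of modest size or none beyond the scatter is therefore expected, with a lean toward a lower number; the expected step is a 1.4-fold lower number from compound 3 to compound 4 (0.15 log units; within the scatter). Compound 4 is estimated at 0.05 nM, within a range of 0.015 nM to 0.2 nM.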

Compound 4, inhibition constant: 0.04 nM
Beside the measured number, compound 4's estimate is 1.3-fold (0.10 log units) above it, and the stated range covers the measured number.
By their numbers in this assay, from the lowest: compounds 4 and 3 (each within the scatter of the next); then compound 2; then compound 1.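

Methyl in place of hydrogen on this aromatic carbon, next to the ring nitrogen and next to the ring atom that bears a large group, now has a measured result: in this assay the change gives a 1.8-fold lower number from compound 3 to compound 4 (0.24 log units; within the scatter). This carbon therefore takes a methyl on the chloro-bearing core with no shift beyond the scatter, and compound 3 and compound 4 cannot be ordered. Although the two methyl groups sit on different aromatic carbons, their steps cannot be told apart: the same change on two cores in this assay, a 4.0-fold lower number (0.60 log units; beyond the scatter) from compound 1 to compound 2 and a 1.8-fold lower number (0.24 log units; within the scatter) from compound 3 to compound 4, 2.3-fold (0.36 log units) apart, within the scatter of two such steps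

The compounds shown leave open how this carbon responds to a group other than methyl, such as an ethyl, a longer chain or an amine. Also open, as far as these compounds go, is whether a methyl here gives a similar step on the core of compound 1, which lacks the chloro group.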